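Growing the furan substituent: ethyl to tert-butyl

The compounds below may be only part of what the source reports. "The series", "measured", "known", "first", "only" and "open" are said of these compounds alone.

Measured compounds:
compound 1 `CC[C@@H](Nc1c(Nc2cccc(C(=O)N(C)C)c2O)c(=O)c1=O)c1cc(C)co1`: 9 nM
compound 2 `CCc1coc([C@@H](CC)Nc2c(Nc3cccc(C(=O)N(C)C)c3O)c(=O)c2=O)c1`: 7 nM

In an assay on CHO cells for displacement of a labelled ligand from C-X-C chemokine receptor type 1 (Homo sapiens) (a lower number here means a stronger inhibitor, a higher number a weaker inhibitor), compound 2 gives 7 nM and stands at the lower of the two numbers, with compound 1 at 9 nM; the step of a 1.3-fold lower number from compound 1 to compound 2 (0.11 log units; within the scatter) lies within the scatter. Compound 3 `CC[C@@H](Nc1c(Nc2cccc(C(=O)N(C)C)c2O)c(=O)c1=O)c1cc(C(C)(C)C)co1` differs from compound 2 by tert-butyl in place of ethyl on an aromatic carbon. Among the compounds with values here, the only measured step that bears on this place is a 1.3-fold lower number from compound 1 to compound 2 (0.11 log units; within the scatter), which is small, so a further enlargement at the same carbon is expected to leave the number roughly unchanged, with an estimated step of a 1.1-fold higher number from compound 2 to compound 3 (0.06 log units; within the scatter). Compound 3 is therefore expected to give about 8 nM in this assay, between 3 nM and 25 nM.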

Compound 3, inhibition constant: 10 nM
The estimate for compound 3 lay 1.3-fold (0.10 log units) below the measured number; measured number inside the range.
By their numbers in this assay, from the lowest: compounds 2, 1 and 3 (each within the scatter of the next).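

In this assay, the larger tert-butyl group on this aromatic carbon of the furan leaves the number within the scatter: the change from ethyl gives a 1.4-fold higher number from compound 2 to compound 3 (0.15 log units; within the scatter) and the change from methyl gives a 1.1-fold higher number from compound 1 to compound 3 (0.05 log units; within the scatter) at the same carbon. The earlier pair spanned only methyl and ethyl, whereas these three compounds show that tert-butyl also cannot be told apart from either. Nothing shown here offers a reason for this. Still open, as far as these compounds go, is whether an amine, a carboxylic acid or a phenyl ring on this carbon would keep the number in the same range.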